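The source may hold more compounds than are shown below. What is called first, only, known or untested is meant among the compounds shown, and "the series" means these compounds.

Working notes on the series.

Compound 1 `CCCCCCCCCCNC[C@@H]1OC[C@H](N)[C@@H]1O` is tested in a functional assay on PC-3 cells (Homo sapiens) for antiproliferative activity, read by MTT assay, with a stated time of 72 h (a lower number here means a stronger inhibitor, a higher number a weaker inhibitor), where compound 1 gives 11900 nM. Of the two numbers in hand this is the highest; the nearest is compound 2 `CCCCCCCCCCCCNC[C@@H]1OC[C@H](N)[C@H]1O`, which in this assay gives 2380 nM, a gap that lies beyond the usual scatter of this measurement. Going by the values given here, no single-change step between compound 1 and compound 2 is on record, so their two values are noted only as they stand.

The next compound to be measured, compound 3 `CCCCCCCCCCCCCCNC[C@@H]1OC[C@H](N)[C@@H]1O`, is reached from compound 1 by one change: butyl in place of hydrogen on a saturated chain carbon, ten or more bonds along the chain from an amine nitrogen. Among the compounds with values here, the only guidance is that compound 2, which also carries a longer saturated chain than compound 1, sits well lower in this assay. On that basis the step from compound 1 to compound 3 is expected to lower the number by a moderate amount, more than the scatter, and the estimated step is a 4.8-fold lower number from compound 1 to compound 3 (0.68 log units; beyond the scatter). For compound 3 the expected value in this assay is 2500 nM, with a range from 700 nM to 9000 nM.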

Compound 3, half-maximal inhibitory concentration: 1200 nM
Estimate against measurement, compound 3: 2.1-fold (0.32 log units) above, and the stated range covers the measured number.
By their numbers in this assay, from the lowest: compounds 3 and 2 (each within the scatter of the next); then compound 1.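

On the core of compound 1, butyl in place of hydrogen on a saturated chain carbon, ten or more bonds along the chain from an amine nitrogen, gives a 9.9-fold lower number from compound 1 to compound 3 (1.00 log units; beyond the scatter) in this assay. Going by these compounds alone, this is the only single-change step on record, and it shows that this place on the chain is not silent: a change there alone moves the number beyond the usual scatter. The earlier compounds shown here could not show this, as compound 1 and compound 2 differ in more than one place and their values could only be noted side by side. Nothing on hand gives a reason for the size of this step.

On these data alone, a single step cannot show the shape of the trend, so it remains open whether a still longer chain would lower the number further, level off or raise it again. Also open, as far as these compounds go, are whether a phenyl group or a carboxylic acid in place of the butyl would keep any of the step, and whether the same butyl change would have a similar effect on the core of compound 2.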